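Cytotoxicity of sulfonamide piperidinylpiperidines: aryl swap on the sulfonyl

A few compounds are considered here, and "the series" means these few. Any claim that something is new, unique, unknown or untested is made for them only; others in the source may bear on it.

Working notes on a small cytotoxicity series. Compound 1 has the structure `CC1CCN(C2CCN(S(=O)(=O)c3cccnc3Cl)CC2)CC1`. In an ADME assay on HCT-116 cells (Homo sapiens) for cytotoxicity, read by CellTiter-Glo, with a stated time of 72 h (on this read-out higher numbers stand for weaker inhibition and lower numbers for stronger inhibition), compound 1 gives only a limit, > 10000 nM, and no number. Compound 2, with the structure `Cc1cc(C)c(S(=O)(=O)N2CCC(N3CCC(CCO)CC3)CC2)c(C)c1`, is the other measured member of the series. In this assay compound 2 likewise gives only a limit, > 5000 nM. Both values shown are thus limits, as noted in the limit of > 10000 nM in this assay, at which 1 of the 2 values shown sits, and (the limit of > 5000 nM in this assay, at which 1 of the 2 values shown sits), so compound 1 cannot be placed above or below compound 2; the two show only that neither reaches measurable inhibition within the tested range. Going by the values given here, no step between measured compounds is available.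

Compound 3, with the structure `CC1CCN(C2CCN(S(=O)(=O)c3nccn3C)CC2)CC1`, is not yet measured. It differs from compound 1 by 1-methyl-1H-imidazol-2-yl in place of 2-chloropyridin-3-yl on a sulfonyl sulfur. The heteroaryl on the sulfonyl sulfur changes while the rest of compound 1 is kept. With both measured members at their limits, the step that the limit leaves unreadable from compound 1 to compound 3 is expected to be none beyond the scatter. Compound 3 is therefore estimated at 15000 nM, with a range from 5000 nM to 50000 nM, most likely reported as a limit.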

Compound 3, half-maximal inhibitory concentration: > 10000 nM
Compound 3: a limit, no number; the forecaster's own chance of this, stated with the estimate: 80%; the middle value does not contradict the limit.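

In this assay compound 3 gives only a limit, > 10000 nM. Compound 1 also gives only a limit, > 10000 nM. Going by these compounds alone, no step between compound 1 and compound 3 can be read: the limit of > 10000 nM in this assay, at which 2 of the 3 values shown sit. The compounds shown leave open whether any group on the sulfonyl sulfur gives a measurable half-maximal inhibitory concentration in this assay.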